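This account rests on a few compounds, and the source may have more. Where it says the series, first, only, none or still open, it means among the compounds named here.

Among the measured compounds shown here, in an ADME assay on N2a cells (Mus musculus) for cytotoxicity, read by MTT assay (on this read-out lower numbers stand for stronger inhibition and higher numbers for weaker inhibition), compound 3 `C#CC[C@H]1C[C@H](n2cccc2C(=O)CC)C(=O)O1` gives 40700 nM, the only actual number in this small set. Compound 1 `C#CC[C@H]1C[C@H](n2cccc2C(C)=O)C(=O)O1` gives > 100000 nM, which is a limit of the assay. Compound 2 `C#CC[C@H]1C[C@H](n2cccc2)C(=O)O1` gives > 100000 nM, also a limit. Compound 4 `C#CC[C@H]1C[C@H](n2cccc2C(=O)C(F)(F)F)C(=O)O1` keeps the shared core and carries one change: trifluoromethyl in place of ethyl on a carbonyl carbon. For the measured compounds named here, two measured steps touch this same carbonyl side chain: an at least 2.4-fold lower number from compound 1 to compound 3 (0.39 log units; beyond the scatter), and an at least 2.4-fold lower number from compound 2 to compound 3 (0.39 log units; beyond the scatter). Both rest on a limit, and neither brings in trifluoromethyl, so they guide the estimate only loosely. Losing the ethyl could move the number back toward the limit. The expected change is a 1.5-fold higher number from compound 3 to compound 4 (0.17 log units; within the scatter), toward weaker inhibition. For compound 4 the estimated value is 60000 nM, with an expected range from 20000 nM to 150000 nM.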

Compound 4, half-maximal inhibitory concentration: 97800 nM
Compound 4: the middle estimate sits 1.6-fold (0.21 log units) below what was measured; measured number inside the range.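

In this assay trifluoromethyl in place of ethyl on a carbonyl carbon gives a 2.4-fold higher number from compound 3 to compound 4 (0.38 log units; beyond the scatter) as a modest step toward weaker inhibition, the first step measured between two actual numbers rather than from a limit. It shows that the group on this carbonyl carbon alters the reading even when the chain length is barely changed. The other two steps, an at least 1.0-fold lower number from compound 2 to compound 4 (0.00 log units; that floor lies within the scatter) and an at least 1.0-fold lower number from compound 1 to compound 4 (0.00 log units; that floor lies within the scatter) as well, tell little, because each starts from a limit: the limit of > 100000 nM in this assay, at which 2 of the 4 values shown sit.

Going by these compounds, whether a longer chain or an amine on this carbonyl carbon would lower the number further remains open.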